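This account rests on a few compounds, and the source may have more. Where it says the series, first, only, none or still open, it means among the compounds named here.

Measured in a functional assay on HepG2 cells (Homo sapiens) for inhibition, read by MTT assay, with a stated time of 48 h; a lower number here means a stronger inhibitor, a higher number a weaker inhibitor: compound 1 `COc1ccc(N(C)c2nc(C)nc3ccccc23)cc1C(=O)OCC[Se]C#N` gives 890 nM, compound 2 `COc1ccc(N(C)c2nc(C)nc3ccccc23)cc1C(=O)OCCC[Se]C#N` gives 340 nM, and compound 3 `COc1ccc(N(C)c2nc(C)nc3ccccc23)cc1C(=O)OCCCCCC[Se]C#N` gives 2650 nM.

Compound 4 `COc1ccc(N(C)c2nc(C)nc3ccccc23)cc1C(=O)OCCCCC[Se]C#N` has not yet been measured. It differs from compound 3 by a group of 3 heavy atoms (1 carbon, 1 nitrogen, 1 selenium; no ring) in place of a group of 4 heavy atoms (2 carbon, 1 nitrogen, 1 selenium; no ring), on a saturated chain carbon, five bonds along the chain from an oxygen next to a carbonyl group. The same kind of change already stands between two measured compounds, (a group of 3 heavy atoms (1 carbon, 1 nitrogen, 1 selenium; no ring) in place of a group of 4 heavy atoms (2 carbon, 1 nitrogen, 1 selenium; no ring), on a saturated chain carbon, two bonds along the chain from an oxygen next to a carbonyl group), and made a step of a 2.6-fold higher number from compound 2 to compound 1 (0.42 log units; beyond the scatter). The two places are not the same word for word: one sits two bonds along the chain from an oxygen next to a carbonyl group, the other five bonds along. Compound 3 differs from compound 2 by a group of 6 heavy atoms (4 carbon, 1 nitrogen, 1 selenium; no ring) in place of a group of 3 heavy atoms (1 carbon, 1 nitrogen, 1 selenium; no ring), on a saturated chain carbon, three bonds along the chain from an oxygen next to a carbonyl group, with a step of a 7.8-fold higher number from compound 2 to compound 3 (0.89 log units; beyond the scatter); from compound 1 to compound 3 the step is a 3.0-fold higher number from compound 1 to compound 3 (0.47 log units; beyond the scatter). Within this short series the intermediate chain of compound 2 carries the lowest number, and the chain of compound 4 lies between those of compound 3 and compound 2. Compound 4 is therefore expected to move in the opposite direction to the earlier step, with an estimated 1.8-fold lower number from compound 3 to compound 4 (0.25 log units; within the scatter). In this assay compound 4 is estimated at 1500 nM, expected to lie between 600 nM and 3500 nM.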

Compound 4, half-maximal inhibitory concentration: 667 nM
Compound 4: middle estimate off by 2.2-fold (0.35 log units), on the high side, within the range that was stated.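

In this assay the change gives a 4.0-fold lower number from compound 3 to compound 4 (0.60 log units; beyond the scatter), opposite in direction to the earlier step made on the shorter chain: the same change on two cores in this assay, a 2.6-fold higher number (0.42 log units; beyond the scatter) from compound 2 to compound 1 and a 4.0-fold lower number (0.60 log units; beyond the scatter) from compound 3 to compound 4, 10-fold (1.02 log units) apart, beyond the scatter of two such steps

The larger change in chain length does not carry over either: the same change on two cores in this assay, a 7.8-fold higher number (0.89 log units; beyond the scatter) from compound 2 to compound 3 and a 1.3-fold lower number (0.13 log units; within the scatter) from compound 1 to compound 4, 10-fold (1.02 log units) apart, beyond the scatter of two such steps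

Compound 4 sits within the scatter of both shorter-chain compounds, with a 2.0-fold higher number from compound 2 to compound 4 (0.29 log units; within the scatter) and a 1.3-fold lower number from compound 1 to compound 4 (0.13 log units; within the scatter), so the size and direction of a change in this chain depend on the chain it is made on, though these data do not show why.

The compounds shown leave open how a chain longer than that of compound 3 would read. They also leave open whether the same chain trend would hold with an amide in place of the ester, or with sulfur in place of selenium.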